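A few compounds are considered here, and "the series" means these few. Any claim that something is new, unique, unknown or untested is made for them only; others in the source may bear on it.

Measured compounds:
compound 1 `Nc1nc2ccccc2c(=O)o1`: > 62500 nM
compound 2 `O=c1oc(Nc2ccccc2I)nc2ccccc12`: 3500 nM
compound 3 `CN(c1nc2ccccc2c(=O)o1)c1ccccc1I`: 1400 nM

All three share one core and were tested in an assay on isolated protein for inhibition of complement C1r subcomponent (Homo sapiens); a lower number here means a stronger inhibitor, a higher number a weaker inhibitor. Compound 1, with a bare amino group on the core, sits at the limit of > 62500 nM in this assay, at which 1 of the 3 values shown sits; this is a limit of the assay, not a measured number. Compound 2 carries a ring bearing iodo on that nitrogen and gives 3500 nM in this assay; of the two numbers actually measured, compound 2 has the higher one, so it is the weaker inhibitor of the two. Compound 3 adds a methyl to the same nitrogen and gives 1400 nM; the step of a 2.5-fold lower number from compound 2 to compound 3 (0.40 log units; beyond the scatter) is modest but real.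

Compound 4 `O=c1oc(Nc2ccccc2Br)nc2ccccc12` differs from compound 2 in one place only: bromo in place of iodo on an aromatic carbon. For the measured compounds named here, the single measured step, a 2.5-fold lower number from compound 2 to compound 3 (0.40 log units; beyond the scatter), changes the nitrogen, not the halogen, so no measured step bears directly on exchanging one halogen for another. Compound 4 is therefore expected to land near compound 2, with the expected step of a 1.3-fold higher number from compound 2 to compound 4 (0.11 log units; within the scatter) staying within the scatter of the assay. The estimate for compound 4 in this assay is 4500 nM, with a range from 1800 nM to 12000 nM.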

Compound 4, half-maximal inhibitory concentration: 5100 nM
For compound 4 the middle estimate is 1.1-fold (0.05 log units) below the measured one, and the stated range covers the measured number.
By their numbers in this assay, from the lowest: compound 3; then compounds 2 and 4 (each within the scatter of the next). At a limit, above all of these: compound 1.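

In this assay the exchange of iodo for bromo gives a 1.5-fold higher number from compound 2 to compound 4 (0.16 log units; within the scatter) and so compound 2 and compound 4 cannot be told apart at this position, an aromatic carbon ortho to a large group. For the compounds shown here, this is the first look at the halogen itself, as the one step known before changed the nitrogen and left the ring untouched; it shows that, in this pair, either halogen can sit on this carbon with no difference that rises above the scatter of the assay. Nothing available here explains why these two halogens give such similar numbers.

The compounds shown say nothing about how chloro, fluoro, methyl, methoxy, an amine or a carboxylic acid would behave on this same carbon, so the tolerance seen covers iodo and bromo only. They also leave open whether a methyl on the nitrogen of compound 4 would bring the same kind of step that it brings to compound 2, since the halogen and the nitrogen have so far been changed only one at a time.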